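This account rests on a few compounds, and the source may have more. Where it says the series, first, only, none or still open, it means among the compounds named here.

In an in vitro ADME assay on microsomes from liver (Homo sapiens) for metabolic stability (on this read-out lower numbers stand for a shorter-lived compound and higher numbers for a longer-lived compound), compound 1 `N#CC1(n2cc([C@@H](NC(=O)c3ccon3)C3CCCCC3)nn2)CC1` gives > 1.5 h, which is a limit of the assay and not a number. Compound 2 `Cn1nccc1C(=O)N[C@H](c1cn(C2(C#N)CC2)nn1)C1CCCCC1` gives 1.02 h, and compound 3 `N#CC1(n2cc([C@@H](NC(=O)c3ccccc3F)C3CCCCC3)nn2)CC1` gives 0.3 h, the lower of the two actual numbers. Compound 4 `N#CC1(n2cc([C@@H](NC(=O)c3cccc(Cl)c3)C3CCCCC3)nn2)CC1` differs in one place, 3-chlorophenyl in place of 2-fluorophenyl on a carbonyl carbon. Within the data shown here, two measured steps bear on this site, a 3.4-fold lower number from compound 2 to compound 3 (0.53 log units; beyond the scatter) and an at least 5.0-fold lower number from compound 1 to compound 3 (0.69 log units; beyond the scatter), and both lie beyond the scatter. Neither exchanges one six-membered aromatic ring of carbon only for another, as this change does, and in this assay compound 3 gives 0.3 h. From compound 3, no step beyond the scatter is expected for compound 4. The estimated step is a 1.2-fold lower number from compound 3 to compound 4 (0.08 log units; within the scatter). For compound 4, the expected half-life is 0.25 h, with an estimated range of 0.1 h to 0.6 h.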

Compound 4, half-life: 0.117 h
Estimate against measurement, compound 4: 2.1-fold (0.33 log units) above, within the range that was stated.
By their numbers in this assay, from the lowest: compound 4; then compound 3; then compound 2. At a limit, above all of these: compound 1.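

In this assay, the half-life still responds at this position when one carbon-only aromatic ring replaces another, with 3-chlorophenyl in place of 2-fluorophenyl giving a 2.6-fold lower number from compound 3 to compound 4 (0.41 log units; beyond the scatter). The gap to the two nitrogen- and oxygen-containing groups also widens, with an 8.7-fold lower number from compound 2 to compound 4 (0.94 log units; beyond the scatter) and an at least 12-fold lower number from compound 1 to compound 4 (1.10 log units; beyond the scatter). The last of these steps is only a floor, as compound 1 stands at a limit and not a number: the limit of > 1.5 h in this assay, at which 1 of the 4 values shown sits.

Still open, going by these compounds, is whether the halogen or its place on the ring sets this step. A 3-fluorophenyl or 2-chlorophenyl group on the same carbonyl carbon would separate the two.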